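The source may hold more compounds than are shown below. What is called first, only, known or untested is meant among the compounds shown, and "the series" means these compounds.

Compound 2 `COc1ccc2c(=O)c(-c3cc(OC)c(OC)cc3OC)coc2c1` gives 9400 nM in a functional assay on U-251 cells (Homo sapiens) for antiproliferative activity, read by MTT assay, with a stated time of 24 h (on this read-out lower numbers stand for stronger inhibition and higher numbers for weaker inhibition), the higher of the two numbers measured, yet within the scatter of compound 1 `C=CCOc1ccc2c(=O)c(-c3cc(OC)c(OC)cc3OC)coc2c1`, which gives 5900 nM in this assay. Compound 3 `COc1cc(OC)c(-c2coc3cc(OCc4ccc(Br)cc4)ccc3c2=O)cc1OC` differs from compound 2 by 4-bromophenyl in place of hydrogen on a saturated chain carbon bound to an oxygen on an aromatic ring. Going by the values given here, the only measured step at that place is a 1.6-fold higher number from compound 1 to compound 2 (0.20 log units; within the scatter), and it stayed within the scatter. Because a 1.6-fold higher number from compound 1 to compound 2 (0.20 log units; within the scatter) was small, the larger group now entering is expected to shift the number little, if anything slightly downward. Compound 3 is therefore estimated at 5500 nM, within 2000 nM to 16000 nM. That amounts to an expected step of a 1.7-fold lower number from compound 2 to compound 3 (0.23 log units; within the scatter).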

Compound 3, half-maximal inhibitory concentration: 10000 nM
Beside the measured number, compound 3's estimate is 1.8-fold (0.26 log units) below it, within the range that was stated.
By their numbers in this assay, from the lowest: compounds 1, 2 and 3 (each within the scatter of the next).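

In this assay putting 4-bromophenyl on the saturated chain carbon bound to an oxygen on an aromatic ring gives a 1.1-fold higher number from compound 2 to compound 3 (0.03 log units; within the scatter) and a 1.7-fold higher number from compound 1 to compound 3 (0.23 log units; within the scatter) when it takes the place of vinyl. Both steps stay within the scatter, so this place carries a whole six-membered aromatic ring of 7 heavy atoms with no readable change in the number, something hydrogen and vinyl alone could not show. From the compounds shown here alone, whether an amine or a carboxylic acid at this place would move the number remains open. Nothing given here explains these results.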